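The source may hold more compounds than are shown below. What is called first, only, known or untested is meant among the compounds shown, and "the series" means these compounds.

Measured so far in a functional assay on L1210 cells (Mus musculus) for cytotoxicity, read by cell counting, with a stated time of 2 days; on this read-out higher numbers stand for weaker inhibition and lower numbers for stronger inhibition:

Compound 1 `C=C(Br)C(=O)Nc1cccc(/C=C2\SC(=O)N(Cc3cccc(Cl)c3)C2=O)c1` gives 1100 nM in this assay.
Compound 2 `CC(C)(C)c1ccc(CN2C(=O)S/C(=C\c3cccc(N)c3)C2=O)cc1` gives 223000 nM in this assay.
Compound 3 `C=C(Br)C(=O)Nc1cccc(/C=C2\SC(=O)N(Cc3ccccc3)C2=O)c1` gives 380 nM in this assay.

Compound 3 holds the lowest number of the three. Going by the values given here, its nearest neighbour is compound 1, and the single change between them, hydrogen in place of chloro on an aromatic carbon, gives a 2.9-fold lower number from compound 1 to compound 3 (0.46 log units; beyond the scatter). Among the compounds with values here, compound 2 sits far above both; it differs from compound 3 in more than one place, so no single step can be drawn from it, and its value only shows how much weaker that compound is.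

Compound 4 `C=C(Br)C(=O)Nc1cccc(/C=C2\SC(=O)N(Cc3ccc(C(C)(C)C)cc3)C2=O)c1` is the next member. It differs from compound 3 by tert-butyl in place of hydrogen on an aromatic carbon. Compound 2 carries the same tert-butyl group but is not a one-step neighbour of anything measured, so nothing shows what that group alone does. Within the data shown here, the only step on this ring, from compound 1 to compound 3, was modest and concerned a different substituent. Among the measured compounds shown here, with no direct precedent, the expectation for compound 4 is a step no larger than the scatter or only modest, direction uncertain, so a 1.3-fold higher number from compound 3 to compound 4 (0.12 log units; within the scatter) is estimated. Compound 4 is therefore expected near 500 nM, within 180 nM to 1500 nM.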

Compound 4, half-maximal inhibitory concentration: 3200 nM
The estimate for compound 4 lay 6.4-fold (0.81 log units) below the measured number, outside the stated range (above it).
By their numbers in this assay, from the lowest: compound 3; then compound 1; then compound 4; then compound 2.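

In this assay the unsubstituted phenyl of compound 3 now stands below both substituted rings: tert-butyl in place of hydrogen, on an aromatic carbon para to a large group, gives an 8.4-fold higher number from compound 3 to compound 4 (0.93 log units; beyond the scatter) and 4-(tert-butyl)phenyl in place of 3-chlorophenyl gives a 2.9-fold higher number from compound 1 to compound 4 (0.46 log units; beyond the scatter) on the same saturated chain carbon. The first one-step reading of (1-bromoethenyl)carbonyl in place of hydrogen on the nitrogen, with tert-butyl held fixed, is a 70-fold lower number from compound 2 to compound 4 (1.84 log units; beyond the scatter) and this large step sets the weight of that group well above that of either ring change shown. No measurement available here accounts for the rise on adding tert-butyl.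

A methyl, a methoxy or a carboxylic acid on this same aromatic carbon would show whether any group there raises the number or tert-butyl alone does, and the change from 3-chlorophenyl to 4-(tert-butyl)phenyl alters both group and place, so those two remain unseparated. The part played by the bromine also stays unread, and a plain ethenylcarbonyl group in its place on the nitrogen would address it.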